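The compounds below may be only part of what the source reports. "The series", "measured", "known", "first", "only" and "open" are said of these compounds alone.

Compound 1 `COc1ccccc1N1CCN(CCCNc2ncccc2C(=O)N(C)C)CC1`: 1.59 nM in a functional assay for antagonist activity at Alpha-1A adrenergic receptor (Oryctolagus cuniculus); a lower number here means tighter binding, a higher number weaker binding
Compound 2 `COc1ccccc1N1CCN(CCCNc2ncccc2C(=O)C2CC2)CC1`: 0.501 nM
Compound 3 `COc1ccccc1N1CCN(CCCNc2ncc(C#N)cc2C(=O)N(C)C)CC1`: 0.794 nM

Compound 1 stands highest of the three numbers. Its gap to compound 3 is small, a 2.0-fold lower number from compound 1 to compound 3 (0.30 log units; within the scatter), while the step to compound 2 is clearer, a 3.2-fold lower number from compound 1 to compound 2 (0.50 log units; beyond the scatter). Compound 4 `CN(C)C(=O)c1cccnc1NCCCN1CCN(c2ccccc2OCC2CC2)CC1` differs from compound 1 by cyclopropyl in place of hydrogen on a saturated chain carbon bound to an oxygen on an aromatic ring. Neither measured step bears on this part of the molecule: the two known changes sit on the ring that carries the carbonyl, far from the methoxy group, so nothing measured speaks directly to the enlargement here. The author therefore expects compound 4 to stay close to compound 1 in this assay, with no step beyond the scatter, a 1.1-fold lower number from compound 1 to compound 4 (0.03 log units; within the scatter). Compound 4 is estimated at 1.5 nM, between 0.5 nM and 5 nM.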

Compound 4, dissociation constant: 0.159 nM
Estimate against measurement, compound 4: 9.4-fold (0.97 log units) above, and the stated range ends above it.
By their numbers in this assay, from the lowest: compound 4; then compounds 2, 3 and 1 (each within the scatter of the next, the first and the last beyond it).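

In this assay, within the data shown here, replacing methoxy with cyclopropylmethoxy gives a 10-fold lower number from compound 1 to compound 4 (1.00 log units; beyond the scatter) and shows that this end of the molecule, unchanged in the earlier compounds, also affects the number. The oxygen-bound chain carbon accepts a cyclopropyl group without any loss, and the number moves toward tighter binding. Nothing available explains this gain.

From the compounds shown here alone, it remains open whether an ethoxy group, a longer chain or a phenyl group at this place would give a similar number. Going by these compounds, it also remains open whether cyclopropylmethoxy would combine with the cyano or cyclopropyl changes seen elsewhere on the core.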